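Chloro to methoxy beside trifluoromethyl in a diaryl urea series

The source may report more compounds than this note shows. Statements on the series, on what has been measured and on what is new or still open speak of the compounds shown alone.

Compound 1 `O=C(Nc1ccc(Cl)cc1)Nc1cccc(-c2nc(-c3ccc(NC(=O)c4cccnc4)cc3Cl)no2)c1`: > 10000 nM
Compound 2 `COc1cccc(NC(=O)Nc2cccc(-c3nc(-c4ccc(NC(=O)c5cccnc5)cc4Cl)no3)c2)c1`: 6700 nM
Compound 3 `O=C(Nc1cccc(-c2nc(-c3ccc(NC(=O)c4cccnc4)cc3Cl)no2)c1)Nc1ccc(Cl)c(C(F)(F)F)c1`: 1900 nM

Three ureas sharing one core have been tested in a functional assay on MDA-MB-231 cells (Homo sapiens) for antiproliferative activity, read by MTT assay, with a stated time of 72 h; on this read-out higher numbers stand for weaker inhibition and lower numbers for stronger inhibition. Compound 1 gives only a limit, (the limit of > 10000 nM in this assay, at which 1 of the 3 values shown sits), and no number. Compound 2 gives 6700 nM and compound 3 gives 1900 nM; compound 3 thus holds the lowest number of the two that were obtained, and its nearest neighbour, compound 2, is separated from it by a 3.5-fold lower number from compound 2 to compound 3 (0.55 log units; beyond the scatter). The other measured step, an at least 5.2-fold lower number from compound 1 to compound 3 (0.72 log units; beyond the scatter), shows what trifluoromethyl adds, while an at least 1.4-fold lower number from compound 1 to compound 2 (0.17 log units; that floor lies within the scatter) stays within the scatter.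

Compound 4 `COc1ccc(NC(=O)Nc2cccc(-c3nc(-c4ccc(NC(=O)c5cccnc5)cc4Cl)no3)c2)cc1C(F)(F)F` differs from compound 3 by methoxy in place of chloro on an aromatic carbon. For the measured compounds named here, no measured step exchanges chloro for methoxy directly; the nearest evidence is compound 2, which carries methoxy without trifluoromethyl and sits above compound 3. A modest rise in the number, a 1.8-fold higher number from compound 3 to compound 4 (0.27 log units; within the scatter), is therefore expected, keeping the trifluoromethyl gain but losing part of it. Compound 4 is estimated at 3500 nM in this assay, within 1500 nM to 9000 nM.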

Compound 4, half-maximal inhibitory concentration: 1700 nM
The estimate for compound 4 lay 2.1-fold (0.31 log units) above the measured number; low and high end bracket the measured number.
By their numbers in this assay, from the lowest: compounds 4 and 3 (each within the scatter of the next); then compound 2. At a limit, above all of these: compound 1.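

In this assay methoxy in place of chloro, para to a large group and ortho to a trifluoromethyl group, gives a 1.1-fold lower number from compound 3 to compound 4 (0.05 log units; within the scatter) and so the two groups cannot be told apart at this position, something compound 2 alone could not show. The 4-methoxy-3-(trifluoromethyl)phenyl group also gives a 3.9-fold lower number from compound 2 to compound 4 (0.60 log units; beyond the scatter) as a step beyond the scatter, so the gain seen with compound 3 does not depend on chloro. Compound 1 stands only as a limit, so an at least 5.8-fold lower number from compound 1 to compound 4 (0.76 log units; beyond the scatter) is a floor and not an exact size.

Nothing measured among these compounds explains why chloro and methoxy are level here. On these data alone, whether an amine or a carboxylic acid at this position would stay level with compound 3 and compound 4 remains open.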